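Fluoro for Fluoromethyl on a Defined Stereocentre

This account rests on a few compounds, and the source may have more. Where it says the series, first, only, none or still open, it means among the compounds named here.

Measured in an assay on HEK293 cells for displacement of a labelled ligand from Neuronal acetylcholine receptor; alpha3/beta4 (Homo sapiens), read by scintillation counting, with a stated time of 120 min; on this read-out higher numbers stand for weaker inhibition and lower numbers for stronger inhibition:
compound 1 `FCCOc1cccc(-c2cn(C3CN4CCC3CC4)nn2)c1`, 20.9 nM
compound 2 `FCCCOc1cccc(-c2cn([C@@H]3CN4CCC3CC4)nn2)c1`, 19.5 nM
compound 3 `FCCCOc1cccc(-c2cn(C3CN4CCC3CC4)nn2)c1`, 44.4 nM

Compound 3 and compound 2 share every atom and bond; the difference is the two compounds have the same atoms and bonds; at least one stereo element is drawn with a configuration in one of them and without one in the other: 1 of 3 stereo elements differ; a stereocentre at a saturated ring carbon is drawn without a configuration in compound 3 and S in compound 2. The step of a 2.3-fold higher number from compound 2 to compound 3 (0.36 log units; beyond the scatter) goes with the fact that one of compounds 2 and 3 is drawn with a defined configuration and the other without, at the place where they differ. From compound 3 to compound 1 the change is fluoro in place of fluoromethyl on a saturated chain carbon, two bonds along the chain from an oxygen on an aromatic ring, and it gave a 2.1-fold lower number from compound 3 to compound 1 (0.33 log units; beyond the scatter). Compound 2 has the lowest number of the three, and compound 1 stands within the scatter of it.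

Compound 4 `FCCOc1cccc(-c2cn([C@@H]3CN4CCC3CC4)nn2)c1` has not been measured in this assay. It differs from compound 2 by fluoro in place of fluoromethyl on a saturated chain carbon, two bonds along the chain from an oxygen on an aromatic ring, the same change that turned compound 3 into compound 1, now made on the core of compound 2 with its drawn configuration. Because a 2.1-fold lower number from compound 3 to compound 1 (0.33 log units; beyond the scatter) was modest but beyond the scatter, a step of similar size is expected here, a 2.0-fold lower number from compound 2 to compound 4 (0.29 log units; within the scatter). Compound 4 is therefore estimated at 10 nM, with a plausible range from 4 nM to 25 nM.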

Compound 4, inhibition constant: 11.8 nM
Beside the measured number, compound 4's estimate is 1.2-fold (0.07 log units) below it; low and high end bracket the measured number.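

In this assay, the change from 3-fluoropropoxy to 2-fluoroethoxy gave a 1.7-fold lower number from compound 2 to compound 4 (0.22 log units; within the scatter), a step that on its own lies within the scatter. Set beside the earlier step, it shows no detectable difference between the change on the core of compound 3 and on the core of compound 2 with its drawn configuration: the same change on two cores in this assay, a 2.1-fold lower number (0.33 log units; beyond the scatter) from compound 3 to compound 1 and a 1.7-fold lower number (0.22 log units; within the scatter) from compound 2 to compound 4, 1.3-fold (0.11 log units) apart, within the scatter of two such steps. Among the compounds shown here, this rests on only two pairs and does not show that the change would read alike on other cores, and a 1.8-fold lower number from compound 1 to compound 4 (0.25 log units; within the scatter) is also within the scatter, so the 2-fluoroethoxy pair does not separate a drawn configuration from an undrawn one: the fact that one of compounds 1 and 4 is drawn with a defined configuration and the other without, at the place where they differ.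

The compounds shown leave open how either fluorinated chain would read with the stereocentre drawn R. They also leave open how a 4-fluorobutoxy chain or a plain ethoxy group would compare with the 2-fluoroethoxy group on the same core.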